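A few compounds are considered here, and "the series" means these few. Any claim that something is new, unique, unknown or untested is made for them only; others in the source may bear on it.

Measured so far:
- Compound 1 `O=C1CSc2ccccc2N1Cc1cn(-c2cccc([N+](=O)[O-])c2)nn1`: > 30 ug/mL
- Compound 2 `O=C1CSc2ccccc2N1Cc1cn(Cc2cccc([N+](=O)[O-])c2)nn1`: > 30 ug/mL

Both values come from an ADME assay on A-431 cells (Homo sapiens) for inhibition, read by MTT assay, with a stated time of 48 h; on this read-out lower numbers stand for stronger inhibition of growth and higher numbers for weaker inhibition of growth. Compound 2 gives > 30 ug/mL, which is a limit of the assay and not a number. Compound 1 gives > 30 ug/mL, which is also a limit. The two compounds therefore cannot be ranked, and all the evidence so far comes down to one point: the limit of > 30 ug/mL in this assay, at which 2 of the 2 values shown sit.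

Compound 3 `O=C1CSc2ccccc2N1Cc1cn(Cc2ccc([N+](=O)[O-])cc2)nn1` has not yet been measured. It differs from compound 2 in one place: 4-nitrophenyl in place of 3-nitrophenyl on a saturated chain carbon bound to an aromatic nitrogen. Put simply, 4-nitrophenyl stands in place of 3-nitrophenyl on a saturated chain carbon bound to an aromatic nitrogen.

Within the data shown here, no measured step shows what such a change does, so no shift beyond the usual scatter is expected in this assay. This expectation rests on compound 2, which gives > 30 ug/mL. The expected change is small: a step that the limit leaves unreadable from compound 2 to compound 3. Another limit is the most likely report. As a number, the estimate for compound 3 is 40 ug/mL, within an expected range of 18 ug/mL to 90 ug/mL.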

Compound 3, concentration for 50% growth inhibition: > 30 ug/mL
Compound 3 ended at the assay's limit; the forecaster's own chance of this, stated with the estimate: 80%; the middle value lies beyond the limit too.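

Compound 3 gives > 30 ug/mL in this assay, which is a limit of the assay and not a number. Compound 2 also sits at a limit, so no step can be read between compound 2 and compound 3. The compounds shown leave open how strongly any of them inhibits growth, since all the evidence comes down to one point: the limit of > 30 ug/mL in this assay, at which 3 of the 3 values shown sit.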